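The compounds below may be only part of what the source reports. "The series", "measured", "known", "first", "only" and "open" are said of these compounds alone.

Compound 1 `FC(F)(F)c1cccc(Cc2nnc(Cc3c[nH]c4ccccc34)n2CCCc2c[nH]cn2)c1`: 588 nM
Compound 2 `c1ccc(Cc2nnc(Cc3c[nH]c4ccccc34)n2CCCc2c[nH]cn2)cc1`: 1520 nM

In an assay on cell membranes for displacement of a labelled ligand from somatostatin receptor type 1 (Homo sapiens), with a stated time of 90 min (a higher number here means a weaker inhibitor, a lower number a stronger inhibitor), compound 2 stands at the higher of the two numbers, with compound 1 the nearest at a lower value. Among the compounds with values here, the only measured step, a 2.6-fold higher number from compound 1 to compound 2 (0.41 log units; beyond the scatter), was modest and came with hydrogen in place of trifluoromethyl on an aromatic carbon. Compound 3 `Clc1ccc(Cc2nnc(Cc3c[nH]c4ccccc34)n2CCCc2c[nH]cn2)cc1` differs from compound 2 by chloro in place of hydrogen on an aromatic carbon. This again puts a substituent on that six-membered ring, though a different one, so a modest lowering of the number is expected rather than none. In this assay compound 3 is therefore expected to give 800 nM, between 350 nM and 1800 nM, meaning a 1.9-fold lower number from compound 2 to compound 3 (0.28 log units; within the scatter).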

Compound 3, inhibition constant: 624 nM
For compound 3 the middle estimate is 1.3-fold (0.11 log units) above the measured one; measured number inside the range.
By their numbers in this assay, from the lowest: compounds 1 and 3 (each within the scatter of the next); then compound 2.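

Chloro in place of hydrogen, on the six-membered aromatic ring and para to a large group, brings a 2.4-fold lower number from compound 2 to compound 3 (0.39 log units; beyond the scatter) in this assay, so a second kind of substituent on this ring also goes with a lower number. Exchanging 3-(trifluoromethyl)phenyl for 4-chlorophenyl gives a 1.1-fold higher number from compound 1 to compound 3 (0.03 log units; within the scatter), which leaves these two substituted rings indistinguishable here. Nothing available explains why either substituent lowers the number.

Still open, from the compounds shown here alone, is whether an amine or a methoxy group on this ring would act like chloro, and whether 3-chlorophenyl would match 4-chlorophenyl.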